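A few compounds are considered here, and "the series" means these few. Any claim that something is new, unique, unknown or untested is made for them only; others in the source may bear on it.

Working notes on the series in a functional assay on MCF7 cells (Homo sapiens) for cytotoxicity, read by sulforhodamine B assay, with a stated time of 24 h; a lower number here means a stronger inhibitor, a higher number a weaker inhibitor.

Of the compounds shown here, three sharing one core have been measured. Compound 1 `N/N=C1\C(=O)Nc2ccc(S(=O)(=O)N3CCOCC3)cc21` gives 46800 nM in this assay. Compound 2 `N#CCC(=O)N/N=C1\C(=O)Nc2ccc(S(=O)(=O)N3CCOCC3)cc21` gives 27700 nM. Compound 3 `O=C1Nc2ccc(S(=O)(=O)N3CCOCC3)cc2/C1=N/c1ccc(Cl)cc1` gives 44300 nM. Compound 2 has the lowest of the three numbers, but its nearest neighbour compound 3 and its furthest neighbour compound 1 both sit within the scatter of it, so no order among the three can be claimed. The measured steps are a 1.7-fold lower number from compound 1 to compound 2 (0.23 log units; within the scatter), a 1.1-fold lower number from compound 1 to compound 3 (0.02 log units; within the scatter) and a 1.6-fold higher number from compound 2 to compound 3 (0.20 log units; within the scatter), all within the scatter.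

Compound 4 `CC(=O)c1cccc(/N=C2\C(=O)Nc3ccc(S(=O)(=O)N4CCOCC4)cc32)c1` is the next to be measured. Its difference from compound 2 is 3-acetylphenyl in place of ((cyanomethyl)carbonyl)amino on a double-bonded nitrogen.

Among the compounds with values here, the step that bears most directly on this change is the one from compound 2 to compound 3, where a 4-chlorophenyl also replaced ((cyanomethyl)carbonyl)amino on the double-bonded nitrogen; that step was a 1.6-fold higher number from compound 2 to compound 3 (0.20 log units; within the scatter). Within the data shown here, no step from a chlorophenyl to an acetylphenyl exists in this set. On this basis no step beyond the scatter is expected in this assay for the change from compound 2 to compound 4, and the expected step is a 1.4-fold higher number from compound 2 to compound 4 (0.14 log units; within the scatter). Compound 4 is therefore estimated at 38000 nM, with a range from 18000 nM to 80000 nM.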

Compound 4, half-maximal inhibitory concentration: 39200 nM
For compound 4 the middle estimate is 1.0-fold (0.01 log units) below the measured one; low and high end bracket the measured number.
By their numbers in this assay, from the lowest: compounds 2, 4, 3 and 1 (each within the scatter of the next).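

In this assay, within the data shown here, the step of a 1.1-fold lower number from compound 3 to compound 4 (0.05 log units; within the scatter) is the first between two substituted phenyl groups on the double-bonded nitrogen, and it stays within the scatter, although 3-acetylphenyl and 4-chlorophenyl differ in both the group and the number in their names. The steps of a 1.4-fold higher number from compound 2 to compound 4 (0.15 log units; within the scatter) and a 1.2-fold lower number from compound 1 to compound 4 (0.08 log units; within the scatter) also stay within the scatter, so a second group with a six-membered aromatic ring of carbon only gives no separation from ((cyanomethyl)carbonyl)amino or amino, and the four groups now seen at this place cannot be told apart by this read-out. No measurement bears on why the number stays within the scatter across these groups.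

As far as these compounds go, since 3-acetylphenyl and 4-chlorophenyl differ in two respects at once, it remains open whether the acetyl group placed as in a 4-acetylphenyl, or a chlorine placed as in a 3-chlorophenyl, would give a step beyond the scatter. From the compounds shown here alone, it also remains open whether an amine or a carboxylic acid on the phenyl ring, or a longer chain carrying that ring on the double-bonded nitrogen, would move the number beyond the scatter.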